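Changing the Ring on the Ether Oxygen of Compound 1

A few compounds are considered here, and "the series" means these few. Any claim that something is new, unique, unknown or untested is made for them only; others in the source may bear on it.

Compound 1 `CCc1nn(C)c(CO/N=C/c2c(C)nn(C)c2Oc2ccc(Cl)cc2)c1Cl`: < 80%
Compound 2 `COc1ccc(Oc2c(/C=N\OCc3c(Cl)c(-c4ccc(F)cc4)nn3C)c(C)nn2C)cc1`: 80%
Compound 3 `Cc1nn(C)c(Oc2ccc(F)cc2)c1/C=N\OCc1c(Cl)c(-c2ccc(Cl)cc2)nn1C`: 80%

Three compounds were measured in a functional assay on SMMC-7721 cells (Homo sapiens) for inhibition, read by MTT assay, with a stated time of 72 h, tested at 25 uM; on this read-out lower numbers stand for less inhibition and higher numbers for more inhibition at the one concentration tested (going by the name of the read-out). Compound 1 returns only a limit of the assay, < 80%, and not a number; (the limit of < 80% in this assay, at which 1 of the 3 values shown sits). Compound 2 gives 80% in this assay. Compound 3 gives 80% in this assay. Among the measured compounds shown here, compound 2 and compound 3 thus sit at the same value, and no single-point change links either of them to compound 1, so no measured step can be drawn from these three.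

Compound 4 `CCc1nn(C)c(CO/N=C/c2c(C)nn(C)c2Oc2ccccc2C)c1Cl` has not been measured. It differs from compound 1 in one place: 2-methylphenyl in place of 4-chlorophenyl on an oxygen on an aromatic ring.

For the measured compounds named here, with no measured step available, the expectation for compound 4 rests on the position of compound 1 alone. Compound 1 stands at the limit, and a change of the ring on the ether oxygen gives no measured ground to expect movement away from it. Compound 4 is therefore expected to give 45% in this assay, within a range from 10% to 79%. The step expected a step that the limit leaves unreadable from compound 1 to compound 4 is none beyond the scatter, with a good chance that compound 4 is again reported only as a limit.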

Compound 4, a percentage reported as inhibition, at one concentration (the size of the read-out at that concentration, not a potency): < 80%
Compound 4: only a limit was reported (the forecaster's own chance of this, stated with the estimate: 60%); the middle value does not contradict the limit.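

Compound 1 and compound 4 are both reported only as limits, so no step can be read for 2-methylphenyl in place of 4-chlorophenyl on an oxygen on an aromatic ring: the limit of < 80% in this assay, at which 2 of the 4 values shown sit.

The compounds shown leave open whether this change moves inhibition in this assay at all, and in which direction.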